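This account rests on a few compounds, and the source may have more. Where it says the series, first, only, none or still open, it means among the compounds named here.

Two compounds have been measured in a functional assay on the whole organism (strain albino) with Mus musculus as the target, with a stated time of 0.5 h; a lower number here means that less compound is needed, a higher number that more compound is needed for the effect:

compound 1 `COc1ccc(/C=C2/N=C(c3ccccc3)N(C(=O)c3ccc(Cl)cc3)NC2=O)cc1`, 100 mg/kg
compound 2 `Cc1ccc(/C=C2/N=C(c3ccccc3)N(C(=O)c3ccc(Cl)cc3)NC2=O)cc1`, 100 mg/kg

Within the data shown here, compound 1 stands level with compound 2 on these numbers, and the one step between them, no change at the digits printed from compound 1 to compound 2 (within the scatter), lies within the scatter. Compound 3 `COc1ccc(/C=C2/N=C(c3ccccc3)N(C(=O)c3ccc(C)cc3)NC2=O)cc1` is not yet measured. It differs from compound 1 as follows: methyl in place of chloro on an aromatic carbon. Among the measured compounds shown here, no measured step touches this ring or this exchange; the only step in hand, from compound 1 to compound 2, concerns the other aromatic ring and was flat. On that slim basis there is no reason to expect a shift beyond the scatter in this assay for compound 3 in either direction. The estimate for compound 3 is therefore 100 mg/kg, within 50 mg/kg to 200 mg/kg, which corresponds to an expected step of no change at the digits printed from compound 1 to compound 3 (within the scatter).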

Compound 3, dose for half-maximal effect: 100 mg/kg
Beside the measured number, compound 3's estimate shows no gap at the digits printed; the measured number falls inside the stated range.
By their numbers in this assay, from the lowest: compounds 1, 2 and 3 (each within the scatter of the next).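

In this assay, among these compounds, methyl in place of chloro on the (4-chlorophenyl)carbonyl group gives no change at the digits printed from compound 1 to compound 3 (within the scatter) and so provides the first reading at this position, para to a large group. The earlier step concerned only the methoxy on the other aromatic ring, whereas this one shows that the read-out also stays within the scatter when 4-chlorophenyl becomes 4-methylphenyl. Nothing at hand offers an explanation for this flat result.

In this assay the compounds shown leave open whether an amine or a carboxylic acid at this position would move the dose beyond the scatter. As far as these compounds go, all three compounds read level, and it remains open which part of the core of compound 1, if any, this read-out responds to.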